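The source may hold more compounds than are shown below. What is called first, only, known or untested is meant among the compounds shown, and "the series" means these compounds.

In an ADME assay on L6 cells (Rattus norvegicus) for cytotoxicity, with a stated time of 72 h (a lower number here means a stronger inhibitor, a higher number a weaker inhibitor), compound 1 (`CC(=O)OC1CC2(N(C)C)CC(c3ccccc3)C1C(c1ccccc1)C2`) has "not determined" (no result reported) as its entry and so offers no number for comparison. Compound 2 (`CN(C)C12CC(OC(=O)CN3CCCC3)C(C(c3ccccc3)C1)C(c1ccccc1)C2`) gives 32700 nM as its result. Compound 3 (`CC(C)(C)C(=O)OC1CC2(N3CCCC3)CC(c3ccccc3)C1C(c1ccccc1)C2`) gives 7620 nM as the lower of the two numbers available, and its gap to compound 2 lies beyond the usual scatter.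

Compound 4 (`CC(C)(C)C(=O)OC1CC2(N3CCCCC3)CC(c3ccccc3)C1C(c1ccccc1)C2`) has not yet been measured. It differs from compound 3 by piperidin-1-yl in place of pyrrolidin-1-yl on a saturated ring carbon. Among the compounds with values here, no measured pair shows this change alone, so the data give no direct guide to its size. With compound 3 at 7620 nM as the starting point, the expected outcome is a small move toward a lower number that stays within the scatter (a 1.3-fold lower number from compound 3 to compound 4 (0.10 log units; within the scatter)). Compound 4 is estimated at 6000 nM with an expected range from 2500 nM to 14000 nM as its span.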

Compound 4, half-maximal inhibitory concentration: 12000 nM
Estimate against measurement, compound 4: 2.0-fold (0.30 log units) below, and the stated range covers the measured number.
By their numbers in this assay, from the lowest: compounds 3 and 4 (each within the scatter of the next); then compound 2.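

Within the data shown here, the step gives the first direct reading of a change at this saturated ring carbon in this assay: with the ((tert-butyl)carbonyl)oxy group held constant, piperidin-1-yl in place of pyrrolidin-1-yl gives a 1.6-fold higher number from compound 3 to compound 4 (0.20 log units; within the scatter). At this position, therefore, the five-membered and the six-membered non-aromatic ring cannot be told apart in this read-out, and the two compounds stand level within the scatter. No measurement shown offers an explanation for this result.

The compounds shown leave open whether morpholin-4-yl or an open-chain amine such as diethylamino on this carbon would also stay within the scatter of compound 3. They also leave open whether a benzoyl ester in place of the ((tert-butyl)carbonyl)oxy group would keep the two amine rings level.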